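A Fluorine on the Far Phenyl of Compound 1

The compounds below may be only part of what the source reports. "The series", "measured", "known", "first", "only" and "open" are said of these compounds alone.

Compound 1, `O=C(Nc1nc2ccccc2s1)c1cn(-c2ccccc2)nc1-c1ccccc1`, is tested in a functional assay on HT-29 cells (Homo sapiens) for cytotoxicity, read by MTT assay, with a stated time of 72 h (a higher number here means a weaker inhibitor, a lower number a stronger inhibitor), where compound 1 gives 16800 nM. Among the compounds with values here, that is the only firm number in this small set. Compound 2, `COc1ccc2nc(NC(=O)c3cn(-c4ccccc4)nc3-c3ccccc3)sc2c1`, reaches only the assay limit of > 50000 nM. Compound 3, `Cc1ccc2nc(NC(=O)c3cn(-c4ccccc4)nc3-c3ccccc3)sc2c1`, likewise reaches only the limit of > 50000 nM. Two of the three values thus sit at the limit of > 50000 nM in this assay, at which 2 of the 3 values shown sit. Both additions to the shared core weaken inhibition: an at least 2.9-fold higher number from compound 1 to compound 2 (0.47 log units; beyond the scatter) and an at least 2.9-fold higher number from compound 1 to compound 3 (0.47 log units; beyond the scatter). Compound 4, `O=C(Nc1nc2ccccc2s1)c1cn(-c2ccccc2)nc1-c1ccc(F)cc1`, differs from compound 1 by fluoro in place of hydrogen on an aromatic carbon, phenyl to 4-fluorophenyl. No measured step touches this ring, so the steps shown bear only loosely, suggesting that small additions tend to weaken rather than strengthen inhibition. Compound 4 is therefore expected at 22000 nM, between 8000 nM and 60000 nM, which means an estimated step of a 1.3-fold higher number from compound 1 to compound 4 (0.12 log units; within the scatter).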

Compound 4, half-maximal inhibitory concentration: 9060 nM
Compound 4: the middle estimate sits 2.4-fold (0.39 log units) above what was measured, and the stated range covers the measured number.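

Going from phenyl to 4-fluorophenyl gives a 1.9-fold lower number from compound 1 to compound 4 (0.27 log units; within the scatter) and so shows no readable shift, which means this position accepts fluoro without the loss seen elsewhere on the shared core. The methoxy and methyl changes in compound 2 and compound 3 gave steps beyond the scatter, so small additions do not weaken inhibition everywhere on this core. Nothing measured here explains why this step differs from those two.

As far as these compounds go, whether chloro, an amine or a carboxylic acid at this position would move the number beyond the scatter stays open. So does whether any group here could strengthen inhibition.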